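Trading a Cyclopropyl Ether for a Methyl Ether

The source may report more compounds than this note shows. Statements on the series, on what has been measured and on what is new or still open speak of the compounds shown alone.

In an ADME assay on a cell-free system (plasma, Rattus norvegicus) for protein binding, read by LC-MS, using equilibrium dialysis, with a stated time of 4 h (on this read-out lower numbers stand for a smaller free fraction and higher numbers for a larger free fraction), three compounds sharing one core have been measured. Compound 1 `CCCOc1ccc(C(=O)Nc2cc(OC(F)(F)F)ccc2-n2cncn2)cc1OC`, with a propyl on an oxygen, gives 0.017. Compound 2 `COc1cc(C(=O)Nc2cc(OC(F)(F)F)ccc2-n2cncn2)ccc1OC(C)C`, with an isopropyl there, gives 0.065, and compound 3 `COc1cc(C(=O)Nc2cc(OC(F)(F)F)ccc2-n2cncn2)ccc1OC1CC1`, with a cyclopropyl, gives 0.052. Two steps show where compound 3 stands: a 1.3-fold lower number from compound 2 to compound 3 (0.10 log units; within the scatter), so those two are level, while a 3.1-fold higher number from compound 1 to compound 3 (0.49 log units; beyond the scatter).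

Compound 4 `COc1ccc(C(=O)Nc2cc(OC(F)(F)F)ccc2-n2cncn2)cc1OC` differs from compound 3 in one place: methyl in place of cyclopropyl on an oxygen on an aromatic ring. Methyl takes the place of cyclopropyl on an oxygen on an aromatic ring, turning cyclopropyloxy into methoxy.

Within the data shown here, no measured step makes this exact swap, so the evidence is indirect. Moving away from the propyl of compound 1 brought modest rises, seen in a 3.8-fold higher number from compound 1 to compound 2 (0.58 log units; beyond the scatter) and again in a 3.1-fold higher number from compound 1 to compound 3 (0.49 log units; beyond the scatter). Exchanging one non-propyl group for another did much less, as a 1.3-fold lower number from compound 2 to compound 3 (0.10 log units; within the scatter) shows. Methyl is also not a propyl, so the closest precedent is this last, small step, with a slight lean upward. The estimated change is a 1.3-fold higher number from compound 3 to compound 4 (0.13 log units; within the scatter). For compound 4, the expected unbound fraction is 0.07, with an estimated range from 0.03 to 0.15.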

Compound 4, unbound fraction: 0.244
Beside the measured number, compound 4's estimate is 3.5-fold (0.54 log units) below it, outside the stated range (above it).
By their numbers in this assay, from the lowest: compound 1; then compounds 3 and 2 (each within the scatter of the next); then compound 4.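

Among these compounds, this result shows that the group on this oxygen matters more than the earlier compounds suggested: in this assay, the swap to methyl is not a small exchange between non-propyl groups, as there is a 4.7-fold higher number from compound 3 to compound 4 (0.67 log units; beyond the scatter) and also a 3.8-fold higher number from compound 2 to compound 4 (0.57 log units; beyond the scatter). Among the compounds shown here, measured from the propyl ether, the same position gives the only large step in the set, with a 14-fold higher number from compound 1 to compound 4 (1.16 log units; beyond the scatter), so the full span of unbound fraction seen here comes from changing this one group. Compound 2 and compound 3 remain level with each other, while compound 4 has the highest number of the four, with each of its steps beyond the scatter, so the series does not climb evenly: the clear separation from those two appears only with methyl.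

The data offer no measurement that accounts for why methyl stands apart from isopropyl and cyclopropyl on this oxygen. Going by these compounds, it also remains open whether an ethyl group or a free hydroxyl at this place would give a number close to that of compound 4 or fall back toward those of compound 2 and compound 3.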